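A few compounds are considered here, and "the series" means these few. Any claim that something is new, unique, unknown or untested is made for them only; others in the source may bear on it.

Compounds measured:
Compound 1 `COc1cc2c(/C=C3/C(=O)Nc4ccc(O)cc43)c(Cl)n(Cc3cc(OC)c(OC)c(OC)c3)c2cc1C`: 43700 nM
Compound 2 `O=C1Nc2ccccc2/C1=C\c1c(Cl)n(Cc2ccccc2)c2ccccc12`: 66100 nM
Compound 3 `O=C1Nc2ccccc2/C1=C\c1c(Cl)n(CCCc2ccccc2)c2ccccc12`: 72400 nM

In a functional assay on cells (Cancer cell lines, Homo sapiens) for cytotoxicity, with a stated time of 48 h (a higher number here means a weaker inhibitor of growth, a lower number a stronger inhibitor of growth), compound 1 gives 43700 nM, compound 2 gives 66100 nM and compound 3 gives 72400 nM. Among the measured compounds shown here, the three numbers lie close together, and the only single-point step among them, a 1.1-fold higher number from compound 2 to compound 3 (0.04 log units; within the scatter), is within the scatter. Compound 3 therefore stands among its neighbours without a gap that can be read as a difference.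

Compound 4 `O=C1Nc2ccc(Cl)cc2/C1=C\c1c(Cl)n(CCCc2ccccc2)c2ccccc12` is obtained from compound 3 by chloro in place of hydrogen on an aromatic carbon. For the measured compounds named here, no measured step touches this position: the step from compound 2 to compound 3 concerns the chain on the aromatic nitrogen, and compound 1 differs from compound 3 in several places at once, so its number cannot be tied to any one change. With nothing to point either way, the step of a 1.0-fold lower number from compound 3 to compound 4 (0.01 log units; within the scatter) in this assay is expected to stay within the scatter. Compound 4 is accordingly estimated at 70000 nM, with a range from 35000 nM to 140000 nM.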

Compound 4, concentration for total growth inhibition: 23400 nM
Beside the measured number, compound 4's estimate is 3.0-fold (0.48 log units) above it; measured number below the stated range.
By their numbers in this assay, from the lowest: compounds 4, 1, 2 and 3 (each within the scatter of the next, the first and the last beyond it).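

In this assay, the step of a 3.1-fold lower number from compound 3 to compound 4 (0.49 log units; beyond the scatter) is the only single-point change among these compounds that goes beyond the scatter. It shows that this aromatic carbon, on the six-membered aromatic ring of carbon only, is a place where one added chlorine atom moves the number modestly toward stronger inhibition of growth, something the change in the chain on the aromatic nitrogen did not do. Nothing measured here bears on why chloro has this effect.

Going by these compounds, whether fluoro, methoxy or an amine on the same carbon would give a step of similar size or direction remains open. On these data alone, it is also open whether chloro here would bring the same gain on the chain of compound 2, or whether a second chloro elsewhere on this ring would add to it.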